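Removing One Phosphate Unit From a Nucleotide Agonist

The source may hold more compounds than are shown below. What is called first, only, known or untested is meant among the compounds shown, and "the series" means these compounds.

Measured compounds:
- Compound 1, `CCSc1nc(=O)ccn1[C@@H]1O[C@H](COP(=O)(O)O)[C@@H](O)[C@H]1O`: 1500 nM
- Compound 2, `O=c1ccn([C@@H]2O[C@H](COP(=O)(O)OP(=O)(O)O)[C@@H](O)[C@H]2O)c(SCc2ccccc2)n1`: 6200 nM

Both compounds were tested in an in vitro functional assay on 1321-N1 cells for agonist activity at P2Y purinoceptor 2 (Homo sapiens), read by scintillation proximity assay and inositol phosphate accumulation; on this read-out higher numbers stand for an effect only at larger amounts of compound and lower numbers for an effect already at smaller amounts. Compound 1 gives 1500 nM, and compound 2 gives 6200 nM. Of the two numbers, compound 2 has the higher one, and the gap to compound 1 is beyond the scatter of repeated measurements, so compound 2 acts only at larger amounts than compound 1. The two compounds differ in more than one place, so no single change can be linked to that gap.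

Compound 3, `O=c1ccn([C@@H]2O[C@H](COP(=O)(O)O)[C@@H](O)[C@H]2O)c(SCc2ccccc2)n1`, has not yet been measured. It differs from compound 2 by a hydrogen atom in place of a group of 4 heavy atoms (3 oxygen, 1 phosphorus; no ring), on an oxygen. The shared core with its benzylthio group is kept; only the phosphate chain is shortened.

For the measured compounds named here, no pair of measured compounds shows the effect of this change on its own, so the expectation rests on the range of the two measured numbers. A modest shift toward a higher number is expected for compound 3, with a 1.5-fold higher number from compound 2 to compound 3 (0.16 log units; within the scatter), though a result within the scatter would not be surprising. Compound 3 is expected to give about 9000 nM, within a range from 2500 nM to 30000 nM.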

Compound 3, half-maximal effective concentration: >= 100000 nM
Compound 3 was reported as a limit (the forecaster's own chance of this, stated with the estimate: 15%); at least 11-fold (1.04 log units) between middle value and limit.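

In this assay the entry for compound 3 is a limit and not a number: the limit of >= 100000 nM in this assay, at which 1 of the 3 values shown sits.

Swapping the outer phosphate unit for a hydrogen atom on an oxygen, with the benzylthio group kept, gives an at least 16-fold higher number from compound 2 to compound 3 (1.20 log units; beyond the scatter), so at this position the length of the phosphate chain weighs heavily on this read-out. Compound 1 carries the same short phosphate chain and still has a measurable effect, and the change of phenyl in place of methyl on a saturated chain carbon bound to a sulfur gives an at least 66-fold higher number from compound 1 to compound 3 (1.82 log units; beyond the scatter), which shows that the short chain alone does not remove the effect and that the outcome also depends on what sits on the sulfur.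

Going by these compounds, it remains open how far the true number of compound 3 lies past its limit, and how the ethyl group on the sulfur would fare with the longer phosphate chain of compound 2. On these data alone, it is also open whether a chain of three phosphate units, or a carboxylic acid in place of the phosphate, would change the picture for the benzylthio series.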